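From nitro to trifluoromethyl: expecting compound 3

The compounds below may be only part of what the source reports. "The series", "measured", "known", "first", "only" and "open" are said of these compounds alone.

Measured so far in a functional assay on SMMC-7721 cells (Homo sapiens) for cytotoxicity, read by MTT assay, with a stated time of 24 h; a lower number here means a stronger inhibitor, a higher number a weaker inhibitor
compound 1 `O=C1/C(=C/c2ccncc2)CN(S(=O)(=O)c2ccccc2)C/C1=C\c1ccccc1C(F)(F)F` gives 6540 nM 
compound 2 `O=C1/C(=C/c2ccncc2)CN(S(=O)(=O)c2ccc([N+](=O)[O-])cc2)C/C1=C\c1ccccc1C(F)(F)F` gives > 20000 nM as a limit

Compound 2 has no number in this assay and stands only at the limit of > 20000 nM for that compound. Compound 3 `O=C1/C(=C/c2ccncc2)CN(S(=O)(=O)c2ccc(C(F)(F)F)cc2)C/C1=C\c1ccccc1C(F)(F)F` differs from it by a single change trifluoromethyl in place of nitro on an aromatic carbon in which trifluoromethyl takes the place of nitro on an aromatic carbon, para to a large group. Going by the values given here, the one measured step at this place is an at least 3.0-fold higher number from compound 1 to compound 2 (0.48 log units; beyond the scatter) where nitro replaces hydrogen, and it is open-ended. Among the compounds with values here, no measured compound carries trifluoromethyl here, so the size of the new step stays uncertain. With nitro gone, a modest move to a lower number is expected, with compound 1 at 6540 nM as the nearest measured reference. The expected step is an at least 2.2-fold lower number from compound 2 to compound 3 (0.34 log units; beyond the scatter) and it is an estimate only. Compound 3 is estimated at 9000 nM with an expected range of 3500 nM to 24000 nM and may yet return only a limit.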

Compound 3, half-maximal inhibitory concentration: 3840 nM
Compound 3: middle estimate off by 2.3-fold (0.37 log units), on the high side, and the stated range covers the measured number.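

In this assay, a substituent at this aromatic carbon, para to a large group, does not always go with a higher number: trifluoromethyl in place of nitro gives an at least 5.2-fold lower number from compound 2 to compound 3 (0.71 log units; beyond the scatter). Compound 2 gives a limit and not a number, so that step has no fixed size: the limit of > 20000 nM in this assay, at which 1 of the 3 values shown sits. Trifluoromethyl in place of hydrogen gives a 1.7-fold lower number from compound 1 to compound 3 (0.23 log units; within the scatter), which lies within the scatter, so among these three compounds only nitro stands apart from the unsubstituted compound.

The compounds shown leave open how an amine or a carboxylic acid at this carbon would read in this assay, so three compounds cannot show whether nitro is a lone case. They also leave open whether the trifluoromethyl result holds when other parts of the shared core change.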